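Working notes on the shared core: step to compound 4

This account rests on a few compounds, and the source may have more. Where it says the series, first, only, none or still open, it means among the compounds named here.

Three compounds on the shared core have numbers in an assay on isolated protein (strain Sprague-Dawley) for inhibition of Amine oxidase [flavin-containing] B (Rattus norvegicus), read by spectrophotometry, with a stated time of 5 min; a lower number here means a stronger inhibitor, a higher number a weaker inhibitor. Compound 1 `CCOC(=O)COc1cc(=O)oc2cc(OCc3cccc(Cl)c3)ccc12` gives 1820 nM; compound 2 `CN(C)C(=O)COc1cc(=O)oc2cc(OCc3cccc(Cl)c3)ccc12` gives 501 nM; compound 3 `CCOC(=O)Nc1cc(=O)oc2cc(OCc3cccc(Cl)c3)ccc12` gives 589 nM. Compound 3 stands second highest of the three: the step of a 1.2-fold higher number from compound 2 to compound 3 (0.07 log units; within the scatter) lies within the scatter, while a 3.1-fold lower number from compound 1 to compound 3 (0.49 log units; beyond the scatter) lies beyond it. The remaining measured step is a 3.6-fold lower number from compound 1 to compound 2 (0.56 log units; beyond the scatter), on a carbonyl carbon rather than on the ring.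

Compound 4 `O=c1cc(CO)c2ccc(OCc3cccc(Cl)c3)cc2o1` is not yet measured. It differs from compound 3 by hydroxymethyl in place of (ethoxycarbonyl)amino on an aromatic carbon. Of the measured steps, only a 3.1-fold lower number from compound 1 to compound 3 (0.49 log units; beyond the scatter) and a 1.2-fold higher number from compound 2 to compound 3 (0.07 log units; within the scatter) exchange the group on that aromatic carbon, and each of those exchanged groups still carries a carbonyl, which the hydroxymethyl group does not; they bear on this change only loosely. Among the compounds with values here, both were modest or within the scatter, so for compound 4 no step in this assay beyond the scatter is expected, with wide uncertainty. The estimate for compound 4 is 450 nM, range 90 nM to 2200 nM. The expected step is a 1.3-fold lower number from compound 3 to compound 4 (0.12 log units; within the scatter).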

Compound 4, half-maximal inhibitory concentration: 5.25 nM
Estimate against measurement, compound 4: 86-fold (1.93 log units) above; measured number outside the range, below it.
By their numbers in this assay, from the lowest: compound 4; then compounds 2 and 3 (each within the scatter of the next); then compound 1.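

On the aromatic carbon opposite the ring oxygen, the three earlier groups, each with a carbonyl, differed only modestly or within the scatter in this assay, but hydroxymethyl brings much larger steps: a 110-fold lower number from compound 3 to compound 4 (2.05 log units; beyond the scatter) and a 95-fold lower number from compound 2 to compound 4 (1.98 log units; beyond the scatter) and a 350-fold lower number from compound 1 to compound 4 (2.54 log units; beyond the scatter). Within the data shown here, this position can therefore carry far more of the difference in this assay than the earlier compounds showed, and compound 4 has the lowest number of the four, with its steps to all the others beyond the scatter. Nothing at hand explains the size of these steps.

The change removes the carbonyl and shortens the group at once, leaving those two differences unseparated. A methyl, methoxymethyl, aminomethyl or carboxylic acid group at this position would show whether the hydroxyl of hydroxymethyl matters or the short chain alone is enough.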